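Taking one methoxy off compound 1

The source may hold more compounds than are shown below. What is called first, only, known or untested is meant among the compounds shown, and "the series" means these compounds.

Among the measured compounds shown here, in a functional assay on CCRF-CEM cells (Homo sapiens) for antiproliferative activity, read by sulforhodamine B assay, with a stated time of 48 h (on this read-out higher numbers stand for weaker inhibition and lower numbers for stronger inhibition), compound 1 (`COc1cc(NS(=O)(=O)c2ccc(N3CCNC3=O)cc2)cc(OC)c1OC`) gives 23 nM as the lower of the two numbers so far. Compound 2 (`O=C1NCCN1c1ccc(S(=O)(=O)Nc2cccc(Cl)c2)cc1`) gives 77 nM and that gap lies beyond the usual scatter. Compound 3 (`COc1cc(NS(=O)(=O)c2ccc(N3CCNC3=O)cc2)cc(OC)c1`) has hydrogen in place of methoxy on an aromatic carbon, ortho to two methoxy groups and para to a large group. For the measured compounds named here, no measured pair shows this change alone. In this assay a moderate weakening is expected, with a 3.5-fold higher number from compound 1 to compound 3 (0.54 log units; beyond the scatter) as the estimated step upward. For compound 3 the estimated value is 80 nM with 25 nM to 300 nM as its expected range.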

Compound 3, half-maximal inhibitory concentration: 170 nM
The estimate for compound 3 lay 2.1-fold (0.33 log units) below the measured number; the measured number falls inside the stated range.
By their numbers in this assay, from the lowest: compound 1; then compound 2; then compound 3.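

Among the compounds shown here, this is the first direct comparison at this position, and it shows that the methoxy matters here: in this assay, replacing it with hydrogen gives a 7.4-fold higher number from compound 1 to compound 3 (0.87 log units; beyond the scatter). The two methoxy groups that remain in compound 3 do not on their own keep the low number of compound 1. Nothing measured here explains the loss. Still open, going by these compounds, is whether a different group at this position, such as an ethoxy, a hydroxyl or an amine, would keep the number low, or whether only methoxy does.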